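Extending a prenyl chain on a polycyclic polyprenylated acylphloroglucinol

The compounds below may be only part of what the source reports. "The series", "measured", "known", "first", "only" and "open" are said of these compounds alone.

Measured compounds:
compound 1 `CC(C)=CCC/C(C)=C/C[C@]12C[C@@H](CC=C(C)C)C(C)(C)[C@](CC=C(C)C)(C(=O)CC1=O)C2=O` – 5.6 ug/mL
compound 2 `CC(C)=CCC/C(C)=C/C[C@@H]1C[C@]2(CC=C(C)C)C(=O)[C@@](CC=C(C)C)(C(=O)C(C(=O)c3ccc(O)c(O)c3)=C2O)C1(C)C` – > 20 ug/mL

Of the compounds shown here, two from this series have been tested in a functional assay on SGC-7901 cells (Homo sapiens) for inhibition; a higher number here means a weaker inhibitor, a lower number a stronger inhibitor. Going by the values given here, compound 1 gives 5.6 ug/mL in this assay, which is the only numerical value in the set. For compound 2 the assay reports only a limit, > 20 ug/mL, as stated in the limit of > 20 ug/mL in this assay, at which 1 of the 2 values shown sits, and no further reading. Since compound 1 and compound 2 are not a single-change pair, nothing is said of the step between them beyond what the two values show.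

Compound 3 `CC(C)=CCC/C(C)=C/C[C@@H]1C[C@@]2(C/C=C(\C)CCC=C(C)C)C(=O)CC(=O)[C@](CC=C(C)C)(C2=O)C1(C)C` has not yet been measured in this assay. It is related to compound 1 by one change: 3-methylbut-2-en-1-yl in place of hydrogen on a saturated chain carbon bound to a double-bonded chain carbon. Among the compounds with values here, no measured pair in the set shows the effect of such a change, so there is no directly comparable step to lean on. A change of this kind, 3-methylbut-2-en-1-yl in place of hydrogen, bringing no ring, no hydrogen-bond donors and no hydrogen-bond acceptors, is expected to move the value from compound 1 little if at all, and the step of a 1.1-fold higher number from compound 1 to compound 3 (0.03 log units; within the scatter) is estimated to lie within the usual scatter. Compound 3 is therefore estimated at 6 ug/mL in this assay, with a plausible range from 3 ug/mL to 14 ug/mL.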

Compound 3, half-maximal inhibitory concentration: > 20 ug/mL
Compound 3: only a limit was reported; the forecaster's own chance of this, stated with the estimate: 15%; middle value at least 3.3-fold (0.52 log units) from the limit.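

Placing 3-methylbut-2-en-1-yl in place of hydrogen on a saturated chain carbon bound to a double-bonded chain carbon, which extends a 3-methylbut-2-en-1-yl chain to a 3,7-dimethylocta-2,6-dien-1-yl chain, gives an at least 3.5-fold higher number from compound 1 to compound 3 (0.55 log units; beyond the scatter) in this assay. Going by these compounds alone, this is the first single-change step, and it shows that this position is not indifferent to the length of its chain, even though the entering group brings no ring, no hydrogen-bond donors and no hydrogen-bond acceptors. Compound 3 is known only through a limit of the assay, so the step marks a minimum and not a size: the limit of > 20 ug/mL in this assay, at which 2 of the 3 values shown sit.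

As far as these compounds go, it remains open whether the weakening belongs to this chain alone or would also appear with the same extension on another prenyl chain of the shared core. Nor do the compounds shown tell whether a shorter chain such as ethyl, or a chain ending in a carboxylic acid or an amine, would stay close to compound 1 at 5.6 ug/mL or improve on it.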